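The compounds below may be only part of what the source reports. "The series", "measured", "known", "first", "only" and "open" are said of these compounds alone.

Measured so far:
compound 1, `CCC(C)[C@H](NC(=O)c1cccc(C(N)=O)c1)C(=O)N[C@@H](CCc1ccccc1)C(=O)CO`, 88 nM in an assay on isolated protein for binding affinity to cathepsin S (Homo sapiens); a higher number here means a weaker inhibitor, a lower number a stronger inhibitor
compound 2, `CCC(C)[C@H](NC(=O)c1cccc(CN)c1)C(=O)N[C@@H](CCc1ccccc1)C(=O)CO`, 180 nM in this assay

Compound 2 gives the higher of the two numbers, with a 2.0-fold higher number from compound 1 to compound 2 (0.31 log units; beyond the scatter) separating it from compound 1. Compound 3, `CCC(C)[C@H](NC(=O)OCc1ccccc1)C(=O)N[C@@H](CCc1ccccc1)C(=O)CO`, is not yet measured; it differs from compound 2 in that (benzyloxy in place of 3-(aminomethyl)phenyl on a carbonyl carbon). Within the data shown here, only the step from compound 1 to compound 2 touches this part of the molecule, and it was modest, so the expectation for compound 3 is a step of a 1.2-fold lower number from compound 2 to compound 3 (0.08 log units; within the scatter), roughly flat. Compound 3 is therefore estimated at 150 nM, within a range of 50 nM to 500 nM.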

Compound 3, inhibition constant: 811 nM
Compound 3: the middle estimate sits 5.4-fold (0.73 log units) below what was measured; measured number outside the range, above it.
By their numbers in this assay, from the lowest: compound 1; then compound 2; then compound 3.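

At this carbonyl carbon, benzyloxy gives a 4.5-fold higher number from compound 2 to compound 3 (0.65 log units; beyond the scatter) and a 9.2-fold higher number from compound 1 to compound 3 (0.96 log units; beyond the scatter) in this assay, which leaves compound 3 the weakest inhibitor of the three. The group that enters has the same count of heavy atoms as 3-(aminomethyl)phenyl and also one six-membered aromatic ring, so those counts alone do not fix the number. No measurement at hand gives a cause for these steps. Still open, going by these compounds, is how a carboxylic acid in place of the aminomethyl would read, and whether a longer chain between the carbonyl and the ring would change the number.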